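The compounds below may be only part of what the source reports. "The series", "measured", "known", "first", "only" and "open" are said of these compounds alone.

Compound 1 `CO[C@H]1O[C@@]2(C)CC(=O)[C@@H]3C[C@@]2(O[C@@H]2O[C@H](CO)[C@@H](O)[C@H](O)[C@H]2O)[C@]13COC(=O)c1ccc(O)cc1` gives 90900 nM in a functional assay on RAW264.7 cells (Mus musculus) for inhibition, read by Griess assay, with a stated time of 24 h; a lower number here means a stronger inhibitor, a higher number a weaker inhibitor.
Compound 2 `CCCCO[C@H]1O[C@@]2(C)CC(=O)[C@@H]3C[C@@]2(O[C@@H]2O[C@H](CO)[C@@H](O)[C@H](O)[C@H]2O)[C@]13COC(=O)c1ccc(O)cc1` returns only a limit, > 100000 nM, in this assay.

Compound 2 therefore stands at the limit of > 100000 nM in this assay, at which 1 of the 2 values shown sits, with no number of its own. Going by the values given here, the single measured step, an at least 1.1-fold higher number from compound 1 to compound 2 (0.04 log units; that floor lies within the scatter), alters the saturated chain and not the aromatic ring, so no measured step bears on the change to compound 3 `CCCCO[C@H]1O[C@@]2(C)CC(=O)[C@@H]3C[C@@]2(O[C@@H]2O[C@H](CO)[C@@H](O)[C@H](O)[C@H]2O)[C@]13COC(=O)c1ccccc1`: hydrogen in place of hydroxy on an aromatic carbon. Given that compound 2 is already a limit, compound 3 is expected to show a step that the limit leaves unreadable from compound 2 to compound 3, no movement beyond the scatter. Compound 3 is thus estimated at 150000 nM, within 60000 nM to 400000 nM, and will most likely again be reported as a limit.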

Compound 3, half-maximal inhibitory concentration: > 100000 nM
Compound 3 ended at the assay's limit; the forecaster's own chance of this, stated with the estimate: 75%; the middle value is on the limit's open side.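

Going by these compounds alone, compound 2 and compound 3 both sit at the limit of this assay, so no step between them can be read. The compounds shown leave open what the change from 4-hydroxyphenyl to phenyl does to inhibition away from that limit.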